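Swapping Trifluoromethyl for Cyano on the Shared Core

This account rests on a few compounds, and the source may have more. Where it says the series, first, only, none or still open, it means among the compounds named here.

Compound 1 `COc1ccc(C(=O)Nc2nc3cc(OC)ccc3s2)cc1` gives > 10 ug/mL in a functional assay on NUGC-3 cells (Homo sapiens) for antiproliferative activity, read by sulforhodamine B assay (a higher number here means a weaker inhibitor of growth, a lower number a stronger inhibitor of growth), which is a limit of the assay rather than a number.
Compound 2 `COc1ccc2sc(NC(=O)c3ccc([N+](=O)[O-])cc3)nc2c1` gives > 10 ug/mL in this assay, again a limit.
Compound 3 `COc1ccc2sc(NC(=O)c3ccc(C(F)(F)F)cc3)nc2c1` gives > 10 ug/mL in this assay, also a limit.

Going by the values given here, all three measured compounds share one core and differ only in the single group on the outer aromatic ring: methoxy, nitro or trifluoromethyl. Because every value sits at the limit of > 10 ug/mL in this assay, at which 3 of the 3 values shown sit, none of the steps between them can be sized: a step that the two limits leave unreadable from compound 1 to compound 2, a step that the two limits leave unreadable from compound 1 to compound 3 and a step that the two limits leave unreadable from compound 2 to compound 3. Compound 3 therefore stands where the other two stand, at the limit, with no order among them.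

The next compound, compound 4 `COc1ccc2sc(NC(=O)c3ccc(C#N)cc3)nc2c1`, keeps everything else and changes only (cyano in place of trifluoromethyl on an aromatic carbon). The measured steps bear on this change only in that none of them moved a value off the limit, so no direction can be read from them. The step that the limit leaves unreadable from compound 3 to compound 4 is expected to be unreadable, with the value again most likely reported as a limit. Compound 4 is therefore estimated at 15 ug/mL, with a range from 5 ug/mL to 40 ug/mL in this assay.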

Compound 4, concentration for 50% growth inhibition: > 10 ug/mL
Compound 4: a limit, no number; the forecaster's own chance of this, stated with the estimate: 75%; the middle value lies beyond the limit too.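

Compound 4 sits at the same limit as compound 1, compound 2 and compound 3, so no step among these four compounds can be read: the limit of > 10 ug/mL in this assay, at which 4 of the 4 values shown sit.

The compounds shown leave open whether any single group on the outer aromatic ring would give a measurable number in this assay.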